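Replacing a Large Side Group on the Strongest Antagonist

The compounds below may be only part of what the source reports. "The series", "measured", "known", "first", "only" and "open" are said of these compounds alone.

Of the compounds shown here, three have been measured in a functional assay on U-937 cells (Homo sapiens) for antagonist activity, read by calcium flux; on this read-out higher numbers stand for weaker inhibition and lower numbers for stronger inhibition. Compound 1 `CCCCCCCCCCOc1ccc(CC(O)c2cccc(C(=O)O)c2)nc1CCC(=O)O` gives 3400 nM, and compound 3 `COc1ccc(CCCCCCOc2ccc(CC(O)c3cccc(C(=O)O)c3)nc2/C=C/C(=O)O)cc1` gives 4000 nM. Compound 2 `COc1ccc(CCCCCCCCOc2ccc(C[S+]([O-])c3cccc(NS(=O)(=O)c4ccccc4)c3)nc2/C=C/C(=O)O)cc1` gives 150 nM, the lowest number of the three and beyond the scatter from both others, so it is the strongest inhibitor so far.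

Compound 4 `COc1ccc(CCCCCCCCOc2ccc(C[S+]([O-])c3cccc(OC)c3)nc2/C=C/C(=O)O)cc1` is still unmeasured. It differs from compound 2 in one place, with methoxy in place of (phenylsulfonyl)amino on an aromatic carbon.

For the measured compounds named here, no measured pair differs in only one place, so no direct comparison shows what this swap does. The only hint is indirect: compound 1 and compound 3 also lack (phenylsulfonyl)amino and both show higher numbers than compound 2, but they differ from it elsewhere too. The expected step of a 4.0-fold higher number from compound 2 to compound 4 (0.60 log units; beyond the scatter) is therefore toward weaker inhibition, probably beyond the scatter, though this is uncertain.

Compound 4 is estimated at 600 nM, with an expected range of 150 nM to 2500 nM.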

Compound 4, half-maximal inhibitory concentration: 300 nM
Compound 4: middle estimate off by 2.0-fold (0.30 log units), on the high side; the measured number falls inside the stated range.
By their numbers in this assay, from the lowest: compounds 2 and 4 (each within the scatter of the next); then compounds 1 and 3 (each within the scatter of the next).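

Putting methoxy in place of (phenylsulfonyl)amino on an aromatic carbon gives, in this assay, a 2.0-fold higher number from compound 2 to compound 4 (0.30 log units; within the scatter), so this read-out does not separate the two compounds. For the compounds shown here, this pair is the first direct test of this position, and it shows that a group of 10 heavy atoms carrying an aromatic ring can give way to one of 2 heavy atoms with no change beyond the scatter. Nothing available explains this result.

From the compounds shown here alone, whether other small groups at this position, such as an amine or a nitrile, would also stay within the scatter of compound 2 remains open. Also open, going by these compounds, is whether the same swap would give a similar step in compounds with a different chain or a different linking group.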